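Benzothiophene Cap on a Triazole Hydroxamic Acid Series

A few compounds are considered here, and "the series" means these few. Any claim that something is new, unique, unknown or untested is made for them only; others in the source may bear on it.

Measured in an assay on Sf9 cells for inhibition of protein deacetylase HDAC6 (Homo sapiens), read by fluorescence, with a stated time of 40 min, tested at 100 nM; on this read-out lower numbers stand for less inhibition and higher numbers for more inhibition at the one concentration tested (going by the name of the read-out):
compound 1 `O=C(NO)c1ccc(NCc2nc(-c3ccccc3)nn2-c2ccccc2Cl)cc1` gives 64.6%
compound 2 `Cc1ccccc1-c1nc(CNc2ccc(C(=O)NO)cc2)n(-c2ccccc2)n1` gives 53.2%
compound 3 `NNC(=O)c1ccc(NCc2nc(-c3ccccc3)nn2-c2ccccc2)cc1` gives 10%

Compound 2 stands second of the three numbers. Compound 1 lies higher by a margin beyond the usual scatter, and compound 3, which carries a hydrazide where the other two carry a hydroxamic acid, lies far lower. Compound 4 `O=C(NO)c1ccc(NCc2nc(-c3cc4ccccc4s3)nn2-c2ccccc2)cc1` has not yet been measured in this assay. It differs from compound 2 in a single place: 1-benzothiophen-2-yl in place of 2-methylphenyl on an aromatic carbon. Among the compounds with values here, no pair of measured compounds differs in exactly this way, so the step has no direct precedent. The step from compound 2 to compound 4 is expected to be small, within the scatter, at a number 1.8 percentage points higher from compound 2 to compound 4 (within the scatter). Compound 4 is therefore estimated to give about 55%, with a range from 30% to 75%.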

Compound 4, a percentage reported as inhibition, at one concentration (the size of the read-out at that concentration, not a potency): 65.5%
For compound 4 the middle estimate is 10.5 percentage points below the measured one, and the stated range covers the measured number.
By their numbers in this assay, from the lowest: compound 3; then compound 2; then compounds 1 and 4 (each within the scatter of the next).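

In this assay, the aromatic carbon between two ring nitrogen atoms accepts a larger group with two rings, and inhibition does not fall: 1-benzothiophen-2-yl in place of 2-methylphenyl gives a number 12.3 percentage points higher from compound 2 to compound 4 (beyond the scatter). Within the data shown here, this is the first step that changes this position alone, so it shows that the group here can alter the read-out. No available data explain why the number rose.

Going by these compounds, it remains open whether the sulfur or the second ring matters more, which a naphthyl group at this carbon could help separate. On these data alone, how an amine or a carboxylic acid would fare here also remains open.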